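A few compounds are considered here, and "the series" means these few. Any claim that something is new, unique, unknown or untested is made for them only; others in the source may bear on it.

Measured so far:
compound 1 `COc1ccc(/C=N/NC(=O)Nc2ccc(Oc3ccnc(-c4nncn4CCN(C)C)c3)c(F)c2)c(OC)c1OC` — in a functional assay on U-87MG ATCC cells (Homo sapiens) for cytotoxicity, read by MTT assay, with a stated time of 72 h (on this read-out higher numbers stand for weaker inhibition and lower numbers for stronger inhibition), compound 1 gives 7650 nM
compound 2 `CN(C)CCn1cnnc1-c1cc(Oc2ccc(NC(=O)N/N=C/c3ccc(F)cc3F)cc2F)ccn1` — in this assay compound 2 gives 1900 nM

Among the compounds with values here, compound 2 holds the lower of the two numbers in this assay; the only measured step is a 4.0-fold lower number from compound 1 to compound 2 (0.60 log units; beyond the scatter), which lies beyond the scatter.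

Compound 3 `COc1cc(/C=N/NC(=O)Nc2ccc(Oc3ccnc(-c4nncn4CCN(C)C)c3)c(F)c2)cc(OC)c1OC` differs from compound 2 in one place: 3,4,5-trimethoxyphenyl in place of 2,4-difluorophenyl on a carbon with a double bond to nitrogen. Within the data shown here, the single measured step bears on this change in reverse. That step, a 4.0-fold lower number from compound 1 to compound 2 (0.60 log units; beyond the scatter), accompanied the exchange of a trimethoxyphenyl for the difluorophenyl; compound 3 reinstates a trimethoxyphenyl, though with the three methoxy groups in the 3,4,5-pattern rather than the 2,3,4-pattern of compound 1. Among the measured compounds shown here, no measured pair separates these two patterns, so the allowance for the altered pattern is unknown. A step back towards the number of compound 1 is therefore expected, that is, a higher number in this assay. For compound 3 the expected change is a 2.6-fold higher number from compound 2 to compound 3 (0.42 log units; beyond the scatter). Compound 3 is estimated at 5000 nM, with an expected range from 1900 nM to 13000 nM.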

Compound 3, half-maximal inhibitory concentration: 22500 nM
Estimate against measurement, compound 3: 4.5-fold (0.65 log units) below, outside the stated range (above it).
By their numbers in this assay, from the lowest: compound 2; then compound 1; then compound 3.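

In this assay, the position on a carbon with a double bond to nitrogen proves sensitive to the arrangement of the methoxy groups and not only to their presence: 3,4,5-trimethoxyphenyl in place of 2,3,4-trimethoxyphenyl gives a 2.9-fold higher number from compound 1 to compound 3 (0.47 log units; beyond the scatter) and so separates two isomeric groups. The exchange of 2,4-difluorophenyl for 3,4,5-trimethoxyphenyl gives a 12-fold higher number from compound 2 to compound 3 (1.07 log units; beyond the scatter) as the largest step now on record at this position. Both trimethoxyphenyl compounds have higher numbers than compound 2, so among these three compounds the 2,4-difluorophenyl group has the lowest number, and neither of the others goes against this.

The compounds shown do not tell whether the difference follows from the fluorine atoms, the methoxy groups or their placement, and an unsubstituted phenyl, a chlorophenyl or a single-methoxy phenyl at this position would help to separate these possibilities. No supporting measurement accompanies these numbers, so the difference between the three groups remains unexplained.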